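Replacing thiophen-2-yl with 3-carboxyphenyl in compound 3

The source may hold more compounds than are shown below. What is called first, only, known or untested is meant among the compounds shown, and "the series" means these compounds.

In an ADME assay on S9 fraction from liver (Rattus norvegicus) for metabolic stability, read by LC-MS, using NADPH, with a stated time of 30 min (on this read-out lower numbers stand for a less stable compound and higher numbers for a more stable compound), compound 3 (`CCCCCCCCc1ccc(OCC(=O)Cn2nnc(-c3cccs3)n2)cc1`) gives 8% and compound 1 (`CCCCCCCCc1ccc(OCC(=O)Cn2nnc(-c3cccc(S(=O)(=O)N(C)C)c3)n2)cc1`) gives 9% as a pair within the scatter of each other. Compound 2 (`CCCCCCCCc1ccc(OCC(=O)Cn2nnc(-c3ccncc3)n2)cc1`) gives < 5% as a limit of the assay and not a number. Compound 4 (`CCCCCCCCc1ccc(OCC(=O)Cn2nnc(-c3cccc(C(=O)O)c3)n2)cc1`) carries 3-carboxyphenyl in place of thiophen-2-yl on an aromatic carbon of the shared core (3-carboxyphenyl in place of thiophen-2-yl on an aromatic carbon). The nearest guide is the exchange of 3-(dimethylsulfamoyl)phenyl for thiophen-2-yl, where a number 1 percentage points lower from compound 1 to compound 3 (within the scatter) is the whole effect. So no step beyond the scatter is expected in this assay and the estimated step is a number 2 percentage points higher from compound 3 to compound 4 (within the scatter) in this read-out. For compound 4 the expected value is 10% (4% to 25% as the estimated range).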

Compound 4, percent of the compound remaining: < 5%
Compound 4 was reported as a limit; the forecaster's own chance of this, stated with the estimate: 25%; middle value at least 5 percentage points from the limit.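

In this assay, the result for compound 4 is a limit and not a number, so all that can be stated is a number at least 3 percentage points lower from compound 3 to compound 4 (that floor lies within the scatter) and a number at least 4 percentage points lower from compound 1 to compound 4 (that floor lies within the scatter). Carboxy on this phenyl ring therefore gives no reading above the floor of the assay. Compound 2 and compound 4 cannot be ordered, and the step between them cannot be read: the limit of < 5% in this assay, at which 2 of the 4 values shown sit.

As far as these compounds go, it remains open whether a primary amide or an aminomethyl group in place of the carboxy group would read any differently. Also open, from the compounds shown here alone, is whether a shorter chain in place of the octyl chain would raise these values.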